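The source may report more compounds than this note shows. Statements on the series, on what has been measured and on what is new or still open speak of the compounds shown alone.

Measured so far in a functional assay on HeLa cells (Homo sapiens) for cytotoxicity, read by MTT assay, with a stated time of 24 h; on this read-out higher numbers stand for weaker inhibition and lower numbers for stronger inhibition:
compound 1 `C=CC1CN2CCC1CC2[C@@H](Nc1c(Nc2ccc(C(F)(F)F)cc2)c(=O)c1=O)c1ccnc2ccccc12`: 10800 nM
compound 2 `O=c1c(Nc2ccc3ccccc3c2-c2c(O)ccc3ccccc23)c(N[C@@H]2CCCC[C@H]2N2CCCCC2)c1=O`: > 20000 nM, which is a limit of this assay and not a number

Compound 2 stands at the limit of > 20000 nM in this assay, at which 1 of the 2 values shown sits, so only a bound is known for it. Compound 3 `O=c1c(Nc2ccc3ccccc3c2-c2c(O)ccc3ccccc23)c(N[C@@H]2CCCC[C@H]2N2CCCC2)c1=O` differs from compound 2 by pyrrolidin-1-yl in place of piperidin-1-yl on a saturated ring carbon. For the measured compounds named here, no measured pair of this kind exists, and compound 1 shares no single-point change with compound 2 or compound 3. The step is expected to be a step that the limit leaves unreadable from compound 2 to compound 3, none beyond the scatter. For compound 3 the estimate in this assay is 25000 nM, in the range 8000 nM to 70000 nM, probably again reported only as a limit.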

Compound 3, half-maximal inhibitory concentration: > 20000 nM
Compound 3 ended at the assay's limit (the forecaster's own chance of this, stated with the estimate: 70%); the middle value is on the limit's open side.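

No step can be read from compound 2 to compound 3, as each is reported only as a limit and not a number: the limit of > 20000 nM in this assay, at which 2 of the 3 values shown sit. From the compounds shown here alone, whether pyrrolidin-1-yl in place of piperidin-1-yl on a saturated ring carbon changes the read-out at all remains open.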